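A few compounds are considered here, and "the series" means these few. Any claim that something is new, unique, unknown or untested is made for them only; others in the source may bear on it.

Of the compounds shown here, two have so far been measured in an ADME assay on J774.1 cells (Mus musculus) for cytotoxicity, read by MTT assay, with a stated time of 48 h; on this read-out lower numbers stand for stronger inhibition and higher numbers for weaker inhibition. Compound 1 `Cc1c(C(=O)N/N=C/c2ccccn2)no[n+]1[O-]` reaches only a limit of this assay, reported as > 400000 nM. Compound 2 `O=C(N/N=C/c1ccc2no[n+]([O-])c2c1)c1cccnc1` gives 31000 nM, the only plain number shown. Of the two values, that of compound 1 is a limit (the limit of > 400000 nM in this assay, at which 1 of the 2 values shown sits). Compound 3 `Cc1[nH]cnc1C(=O)N/N=C/c1ccc2no[n+]([O-])c2c1` differs from compound 2 by 5-methyl-1H-imidazol-4-yl in place of pyridin-3-yl on a carbonyl carbon. Among the measured compounds shown here, with no measured pair to compare, the step is expected to be small, toward weaker inhibition or none beyond the scatter, about a 1.5-fold higher number from compound 2 to compound 3 (0.16 log units; within the scatter). Compound 3 is therefore estimated at 45000 nM, between 12000 nM and 170000 nM.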

Compound 3, half-maximal inhibitory concentration: 33900 nM
The estimate for compound 3 lay 1.3-fold (0.12 log units) above the measured number; the range from low to high includes it.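

In this assay, 5-methyl-1H-imidazol-4-yl in place of pyridin-3-yl on a carbonyl carbon gives a 1.1-fold higher number from compound 2 to compound 3 (0.04 log units; within the scatter) and so no real change. On this carbonyl carbon, then, a five-membered aromatic ring with one hydrogen-bond donor reads the same as a six-membered aromatic ring with none. Nothing shown gives a cause for this result. Still open, as far as these compounds go, is whether a non-aromatic group here, such as an amine, a carboxylic acid or a longer alkyl chain, would move the number beyond the scatter.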